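The source may hold more compounds than are shown below. What is called first, only, known or untested is meant among the compounds shown, and "the series" means these compounds.

Of the compounds shown here, three built on one shared core have so far been tested in an ADME assay on PANC-1 cells (Homo sapiens) for cytotoxicity, read by MTT assay; on this read-out higher numbers stand for lower toxicity in this test and lower numbers for higher toxicity in this test. In this assay compound 3 `Cc1nc(-c2cccnc2)sc1-c1nnc(-c2ccccc2)o1` reached only the limit of the test and gives > 100 ug/mL. Compound 1 `Cc1nc(-c2cccnc2)sc1-c1nnc(-c2ccccc2Cl)o1` likewise gives in this assay a limit, > 100 ug/mL. Compound 2 `Cc1nc(-c2cccnc2)sc1-c1nnc(-c2ccc([N+](=O)[O-])cc2)o1` also gives in this assay a limit, > 100 ug/mL. Among the compounds with values here, compound 3 therefore stands where every value so far stands, namely at the limit of > 100 ug/mL in this assay, at which 3 of the 3 values shown sit. The step that the two limits leave unreadable from compound 1 to compound 3 and the step that the two limits leave unreadable from compound 2 to compound 3 each connect two limits, so neither their size nor their direction can be read from the numbers.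

Compound 4 `Cc1nc(-c2cccnc2)sc1-c1nnc(-c2ccc(O)cc2)o1` has not yet been measured in this assay. It differs from compound 3 by hydroxy in place of hydrogen on an aromatic carbon. Both measured steps are exchanges on an aromatic carbon of the same kind, and both ended at the limit without a readable change, so they offer no reason to expect compound 4 to depart from that limit. The step of a number no higher from compound 3 to compound 4 (the limit leaves the size open) is accordingly expected to show no change beyond the scatter. Compound 4 is estimated at 100 ug/mL, within a range from 50 ug/mL to 200 ug/mL, and is most likely to return once more only a limit.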

Compound 4, half-maximal cytotoxic concentration: > 100 ug/mL
Compound 4 gave a limit, no number; the forecaster's own chance of this, stated with the estimate: 85%; the middle value sits exactly at the limit.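

Compound 4, like compound 1, compound 2 and compound 3, returns only a limit in this assay, so none of the steps joining compound 4 to the other three can be read, in size or in direction: the limit of > 100 ug/mL in this assay, at which 4 of the 4 values shown sit.

The compounds shown leave open how the four differ in this test, if they differ at all, and whether any exchange on the phenyl group changes the read-out.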